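One Ring Swap on Compounds Showing Almost No Effect

A few compounds are considered here, and "the series" means these few. Any claim that something is new, unique, unknown or untested is made for them only; others in the source may bear on it.

Measured compounds:
compound 1 `COc1ccc(/C=N/NC(=O)c2cc(OC)c(OC)c(OC)c2)c(OC)c1` gives -6.9%
compound 2 `COc1ccc(OC)c(C2OC(c3cc(OC)c(OC)c(OC)c3)=NN2C(C)=O)c1` gives 0.4%
compound 3 `COc1ccc(OC)c(/C=N/NC(=O)c2cc(OC)c(OC)c(OC)c2)c1` gives 0.1%

All three numbers come from a functional assay on BGC-823 cells (Homo sapiens) for antiproliferative activity, read by MTT assay, tested at 1 uM; on this read-out lower numbers stand for a weaker effect and higher numbers for a stronger effect at the one concentration tested. Each of them sits close to zero, meaning that at the single concentration tested none of the three compounds held back the growth of these stomach cancer cells to any noticeable degree. Compound 2 carries the highest of the three numbers, yet compound 3, the nearest, and compound 1, the furthest away, both lie within the usual scatter of repeated measurements of it. On these numbers, then, the three compounds cannot be told apart: all of them look inactive.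

Compound 4 `COc1cc(C2=NN(C(C)=O)C(c3cccc(F)c3)O2)cc(OC)c1OC` is the next compound to be tested in this assay. It differs from compound 2 in one place: 3-fluorophenyl in place of 2,5-dimethoxyphenyl on a saturated ring carbon. For the measured compounds named here, no pair of already measured compounds differs in a single place, so there is no measured step to lean on. Since compound 2 and its two companions all sit at the bottom of the scale, the expectation is that the step of a number 1.6 percentage points higher from compound 2 to compound 4 (within the scatter) stays within the scatter, with no real movement in either direction. Compound 4 is therefore estimated at 2%, within a range from -10% to 15%.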

Compound 4, a percentage reported as inhibition, at one concentration (the size of the read-out at that concentration, not a potency): 14.7%
Estimate against measurement, compound 4: 12.7 percentage points below; the range from low to high includes it.
By their numbers in this assay, from the lowest: compounds 1, 3 and 2 (each within the scatter of the next); then compound 4.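

In this assay, the swap on the saturated ring carbon produces a real movement, a number 14.3 percentage points higher from compound 2 to compound 4 (beyond the scatter), so this position is not silent: changing the group held there can shift the read-out while the rest of the compound stays the same. The step is modest, and compound 4 gives 14.7%, which means that 3-fluorophenyl in place of 2,5-dimethoxyphenyl brings out only a small effect at the one concentration tested, and this figure says nothing about potency. No measurement at hand says why the number moved.

This single step cannot separate the loss of the methoxy groups from the arrival of the fluorine, since both happen in the same swap, so it remains unclear which of the two matters for the read-out. Also open, as far as these compounds go, is what this same ring carbon would do with a plain phenyl ring, or with a phenyl ring carrying an amine or a carboxylic acid, and whether any such group would move the number further in either direction.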